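Extending the phenolic oxygen of compound 3 toward a basic side chain

This account rests on a few compounds, and the source may have more. Where it says the series, first, only, none or still open, it means among the compounds named here.

Compound 3 `COc1ccc(-c2cc(-c3ccccc3)no2)c(O)c1` carries a free hydroxyl and gives "not determined" (no result reported) in a functional assay on the whole organism (blood, strain Sprague-Dawley albino) with Rattus norvegicus as the target, with stated times of 30 min and 5 h, at a dose of 100 mg/kg by the oral route (a higher number here means more inhibition at the dose given (going by the name of the read-out), a lower number less inhibition), so no number places it on the scale. Its companions are compound 1 `CCN(CC)CCCOc1cc(OC)ccc1-c1cc(-c2ccccc2)no1`, which gives 7.8%, and compound 2 `CCOC(=O)COc1cc(OC)ccc1-c1cc(-c2ccccc2)no1`, which gives "not determined" (no result reported). Compound 4 `CCN(CC)CC(O)COc1cc(OC)ccc1-c1cc(-c2ccccc2)no1` differs from compound 3 by 3-(diethylamino)-2-hydroxypropyl in place of hydrogen on an oxygen on an aromatic ring. Without a measured value for compound 3, the size and direction of the step cannot be stated from the data; any change would be judged only against the scatter once both numbers exist. Compound 4 is expected to show 10%, within 0% to 30%, because compound 1 gives 7.8%.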

Compound 4, a percentage reported as inhibition, in the whole organism at one dose (the size of the read-out at that dose, not a potency): 11.6%
Beside the measured number, compound 4's estimate is 1.6 percentage points below it; the measured number falls inside the stated range.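

In this assay hydroxy in place of hydrogen on a saturated chain carbon bound to two saturated chain carbons gives a number 3.8 percentage points higher from compound 1 to compound 4 (within the scatter) and so makes no difference that can be told apart on this side chain. Compound 3 has no number, so the step from it to compound 4 cannot be read. No supporting measurement bears on this result. Still open, on these data alone, is whether a carboxylic acid, a pyrrolidine in place of the diethylamino group, or a longer chain on this oxygen would read differently at this dose.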